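This account rests on a few compounds, and the source may have more. Where it says the series, first, only, none or still open, it means among the compounds named here.

compound 1 `O=C(Nc1ccc(Cl)cc1)N1CCC[C@H]1c1nc(-c2ccccc2F)no1` in an ADME assay on MCF-10A cells (Homo sapiens) for inhibition, with a stated time of 48 h (a higher number here means a weaker inhibitor, a lower number a stronger inhibitor), gives > 50000 nM
compound 2 `O=C(Nc1ccc(Cl)cc1)N1CCC[C@H]1c1nc(-c2cccc(Br)c2)no1` in this assay gives > 50000 nM

Both values are limits of the assay, not numbers. For the measured compounds named here, compound 2 therefore has only a limit, and so does the one other compound measured. Going by the values given here, the only measured step, a step that the two limits leave unreadable from compound 1 to compound 2, has no readable size.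

Compound 3 `O=C(Nc1ccc(Cl)cc1)N1CCC[C@H]1c1nc(-c2ccc(Cl)cc2)no1` differs from compound 2 by one change: 4-chlorophenyl in place of 3-bromophenyl on an aromatic carbon. For compound 2 and compound 3, no step beyond the scatter is expected in this assay because of the limit of > 50000 nM in this assay, at which 2 of the 2 values shown sit. The expected step is a number no higher from compound 2 to compound 3 (the limit leaves the size open). Compound 3 will probably also report only a limit. For compound 3 the estimated value is 50000 nM, with an expected range from 15000 nM to 100000 nM.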

Compound 3, half-maximal inhibitory concentration: > 50000 nM
Compound 3: a limit, no number; the forecaster's own chance of this, stated with the estimate: 80%; the middle value sits exactly at the limit.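

Compound 3 gives > 50000 nM, which is a limit and not a number. No step from compound 1 or compound 2 to compound 3 can be read: the limit of > 50000 nM in this assay, at which 3 of the 3 values shown sit.

Going by these compounds, whether these three compounds differ at all in this assay remains open.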